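Tolerance of Three Measured Compounds and One Still Unmeasured

The source may hold more compounds than are shown below. What is called first, only, known or untested is meant among the compounds shown, and "the series" means these compounds.

Three compounds have been measured in an ADME assay on Vero 76 cells (Chlorocebus sabaeus) for cytotoxicity, read by MTT assay, with a stated time of 96 h; a lower number here means that less compound is tolerated, a higher number that more compound is tolerated:
Compound 1 `Cc1ccc(C2CC(c3ccccc3)=NN2c2ccc(S(N)(=O)=O)cc2)cc1` gives 20000 nM.
Compound 2 `NS(=O)(=O)c1ccc(N2N=C(c3ccccc3)CC2c2ccccc2Cl)cc1` gives 26000 nM.
Compound 3 `Cc1ccc(C2CC(c3ccc(Oc4ccccc4)cc3)=NN2c2ccc(S(N)(=O)=O)cc2)cc1` gives 86000 nM.

Compound 2 differs from compound 1 by 2-chlorophenyl in place of 4-methylphenyl on a saturated ring carbon, and this brings a 1.3-fold higher number from compound 1 to compound 2 (0.11 log units; within the scatter). Compound 3 carries a different core, and the step from compound 1 to compound 3 is a 4.3-fold higher number from compound 1 to compound 3 (0.63 log units; beyond the scatter), so compound 3 holds the highest number of the three. Within the data shown here, no step is counted between compound 2 and compound 3; their two values simply show compound 3 at the higher number.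

Compound 4 `NS(=O)(=O)c1ccc(N2N=C(c3ccc(Oc4ccccc4)cc3)CC2c2ccccc2Cl)cc1` has not yet been measured in this assay. It differs from compound 3 by 2-chlorophenyl in place of 4-methylphenyl on a saturated ring carbon. This is the same kind of change as that from compound 1 to compound 2, but made on another core: the two cores differ by phenoxy in place of hydrogen on an aromatic carbon. The surroundings of the altered carbon also read differently. In compound 1 it is next to the ring atom that bears a large group and two ring bonds from the ring atom that bears a phenyl group (6 heavy atoms); in compound 3 it is next to the ring atom that bears a 4-sulfamoylphenyl group and two ring bonds from the ring atom that bears a large group.

The step from compound 3 to compound 4 is expected to be small, a 1.2-fold higher number from compound 3 to compound 4 (0.07 log units; within the scatter), because the same kind of change gave a 1.3-fold higher number from compound 1 to compound 2 (0.11 log units; within the scatter). Compound 4 is therefore expected to give about 100000 nM, with a likely range from 50000 nM to 200000 nM.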

Compound 4, half-maximal cytotoxic concentration: 29000 nM
Beside the measured number, compound 4's estimate is 3.4-fold (0.54 log units) above it; measured number below the stated range.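

Placing 2-chlorophenyl in place of 4-methylphenyl on the saturated ring carbon gave a 3.0-fold lower number from compound 3 to compound 4 (0.47 log units; beyond the scatter) in this assay, so this change did not carry over unaltered from the core of compound 1 to the core of compound 3: the same change on two cores in this assay, a 1.3-fold higher number (0.11 log units; within the scatter) from compound 1 to compound 2 and a 3.0-fold lower number (0.47 log units; beyond the scatter) from compound 3 to compound 4, 3.9-fold (0.59 log units) apart, beyond the scatter of two such steps

Read the other way, phenoxy in place of hydrogen on an aromatic carbon gave a 1.1-fold higher number from compound 2 to compound 4 (0.05 log units; within the scatter), so the higher number seen between the two 4-methylphenyl compounds is not repeated between the two 2-chlorophenyl compounds: the same change on two cores in this assay, a 4.3-fold higher number (0.63 log units; beyond the scatter) from compound 1 to compound 3 and a 1.1-fold higher number (0.05 log units; within the scatter) from compound 2 to compound 4, 3.9-fold (0.59 log units) apart, beyond the scatter of two such steps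

Both comparisons rest on the same four compounds and are one observation seen from two sides: it shows that the two changes do not simply add up in this set, but it does not show why, or whether the same would hold on any other core.

The compounds shown carry only two groups on the saturated ring carbon and only hydrogen or phenoxy on the aromatic carbon, so it stays open whether 4-chlorophenyl at the first place, or an amine or a carboxylic acid in place of phenoxy at the second, would follow the pattern of compound 3 or that of compound 4. Going by these compounds, how these four compounds would behave in any other cell line also stays open.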